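Extending a methyl to butyl on the aminopyridine-type nitrogen

A few compounds are considered here, and "the series" means these few. Any claim that something is new, unique, unknown or untested is made for them only; others in the source may bear on it.

Measured compounds:
compound 1 `CCCCNc1nc(C(F)(F)F)ccc1CNC(=O)C(C)c1ccc(NS(C)(=O)=O)c(F)c1`: 9.1 nM
compound 2 `CC(C(=O)NCc1ccc(C(F)(F)F)nc1NCc1ccccc1)c1ccc(NS(C)(=O)=O)c(F)c1`: 15.8 nM
compound 3 `CC(C(=O)NCc1ccc(C(F)(F)F)nc1N(C)C)c1ccc(NS(C)(=O)=O)c(F)c1`: 19.1 nM

Three compounds share one core and differ only in the amine attached to it. In a functional assay on CHO-K1 cells for antagonist activity at transient receptor potential cation channel subfamily V member 1 (Homo sapiens), read by FLIPR (on this read-out lower numbers stand for stronger inhibition and higher numbers for weaker inhibition), compound 1 gives 9.1 nM, compound 2 gives 15.8 nM and compound 3 gives 19.1 nM. Within the data shown here, compound 3 carries the highest number of the three, though its gap to compound 2 lies within the scatter; only the step of a 2.1-fold higher number from compound 1 to compound 3 (0.32 log units; beyond the scatter) is beyond it.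

Compound 4 `CCCCN(C)c1nc(C(F)(F)F)ccc1CNC(=O)C(C)c1ccc(NS(C)(=O)=O)c(F)c1` is not yet measured. It differs from compound 3 by propyl in place of hydrogen on a saturated chain carbon bound to a nitrogen on an aromatic ring. This reaches toward compound 1, which carries a butyl chain on the same nitrogen but no methyl. The step of a 2.1-fold higher number from compound 1 to compound 3 (0.32 log units; beyond the scatter) suggests that restoring the butyl could lower the number a little, while a 1.2-fold higher number from compound 2 to compound 3 (0.08 log units; within the scatter) shows that swapping one chain for another on this nitrogen can also change little. A small step downward in this assay, possibly within the scatter, is therefore expected: a 1.5-fold lower number from compound 3 to compound 4 (0.17 log units; within the scatter). Compound 4 is estimated at 13 nM, within a range of 5 nM to 32 nM.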

Compound 4, inhibition constant: 0.8 nM
The estimate for compound 4 lay 16-fold (1.21 log units) above the measured number; measured number below the stated range.
By their numbers in this assay, from the lowest: compound 4; then compounds 1, 2 and 3 (each within the scatter of the next, the first and the last beyond it).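

In this assay, the amine nitrogen on the aromatic ring proves far more sensitive than the three earlier compounds suggested, since putting butyl in place of one methyl gives a 24-fold lower number from compound 3 to compound 4 (1.38 log units; beyond the scatter). Neither chain accounts for this alone: adding only a methyl to the butylamino nitrogen gives an 11-fold lower number from compound 1 to compound 4 (1.06 log units; beyond the scatter), and butyl(methyl)amino in place of benzylamino gives a 20-fold lower number from compound 2 to compound 4 (1.30 log units; beyond the scatter), so the effect of each group here depends on what else sits on that nitrogen. Nothing measured here bears on why the drop is so large.

The compounds shown cannot say how closely this result depends on the length of the chain, as an ethyl or a hexyl chain in place of butyl would test. They also leave open whether a second butyl chain in place of the methyl would keep the number this low.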